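Diphenylurea piperazine series: step from compound 3 to compound 4

This account rests on a few compounds, and the source may have more. Where it says the series, first, only, none or still open, it means among the compounds named here.

Values in an assay for inhibition of Type-2 angiotensin II receptor (Rattus norvegicus) (on this read-out lower numbers stand for stronger inhibition and higher numbers for weaker inhibition), so far:
compound 1 `CCCCCN(CCCCC)C(=O)N1CCN(C(=O)N(CCCCC)CCCCC)[C@H](C(=O)O)C1`: 82 nM
compound 2 `CCCCCN(CCCCC)C(=O)N1CCN(C(=O)N(c2ccccc2)c2ccccc2)[C@H](CO)C1`: 30 nM
compound 3 `CCCCCN(CCCCC)C(=O)N1CCN(C(=O)N(c2ccccc2)c2cccc(Cl)c2)[C@H](C(=O)O)C1`: 0.4 nM

Compound 3 stands lowest of the three in this assay; compound 2 is nearest and compound 1 furthest, and both gaps lie beyond the usual scatter. Compound 4 `CCCCCN(CCCCC)C(=O)N1CCN(C(=O)N(c2ccccc2)c2ccc(C(=O)O)cc2)[C@H](C(=O)O)C1` differs from compound 3 in one place: 4-carboxyphenyl in place of 3-chlorophenyl on an amide-type nitrogen. Within the data shown here, no measured pair in this set differs in a single place, so there is no step to lean on for the size of this change. A moderate rise in this assay is expected, a 7.5-fold higher number from compound 3 to compound 4 (0.88 log units; beyond the scatter), since none of the three measured compounds tests a carboxylic acid on the diphenylurea part. Compound 4 is estimated at 3 nM, with a range of 0.5 nM to 20 nM.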

Compound 4, half-maximal inhibitory concentration: 180 nM
Beside the measured number, compound 4's estimate is 60-fold (1.78 log units) below it; measured number outside the range, above it.
By their numbers in this assay, from the lowest: compound 3; then compound 2; then compound 1; then compound 4.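

In this assay, among these compounds, 4-carboxyphenyl in place of 3-chlorophenyl on an amide-type nitrogen gives a 450-fold higher number from compound 3 to compound 4 (2.65 log units; beyond the scatter), the first single-place step. This place is therefore sensitive to its aryl group, and the low value of compound 3 does not carry over to this replacement. No measured property bears on the size of this step.

The step changes both the substituent and its numbered ring position, so it remains open which of the two accounts for the rise. A 4-chlorophenyl group on the same nitrogen would separate them.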